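A few compounds are considered here, and "the series" means these few. Any claim that something is new, unique, unknown or untested is made for them only; others in the source may bear on it.

Measured in a functional assay on HCT-116 cells (Homo sapiens) for inhibition, read by sulforhodamine B assay, with a stated time of 48 h; on this read-out higher numbers stand for weaker inhibition of growth and lower numbers for stronger inhibition of growth:
compound 1 `CCN(C(=O)c1cc(C(C)C)c(O)cc1O)c1cccc(NC(=O)CCCCCCC(=O)NO)c1` — 1120 nM
compound 2 `CC(C)c1cc(C(=O)N(C)c2ccc(NC(=O)CCCCCC(=O)NO)cc2)c(O)cc1O` — 3780 nM
compound 3 `CC(C)c1cc(C(=O)N(C)c2cccc(NC(=O)CCCCCCC(=O)NO)c2)c(O)cc1O` — 1170 nM

On these numbers compound 3 is second highest of the three; its nearest neighbour is compound 1, within the scatter, while compound 2 lies beyond it. Among the measured compounds shown here, the one measured step in this assay, a 1.0-fold higher number from compound 1 to compound 3 (0.02 log units; within the scatter), trimmed an ethyl to a methyl on the same amide-type nitrogen and moved nothing. Compound 4 `CC(C)c1cc(C(=O)Nc2cccc(NC(=O)CCCCCCC(=O)NO)c2)c(O)cc1O` goes one step further: hydrogen in place of methyl on an amide-type nitrogen. For the measured compounds named here, this change is an extension of the same strand of alterations, though no measured pair shows it directly. Guided by the flat step from compound 1 to compound 3, compound 4 is expected near compound 3, a 1.0-fold higher number from compound 3 to compound 4 (0.01 log units; within the scatter), giving an estimate of 1200 nM with a range of 500 nM to 3000 nM.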

Compound 4, concentration for 50% growth inhibition: 6230 nM
Beside the measured number, compound 4's estimate is 5.2-fold (0.72 log units) below it; the measured number lies above the stated range.
By their numbers in this assay, from the lowest: compounds 1 and 3 (each within the scatter of the next); then compounds 2 and 4 (each within the scatter of the next).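

In this assay the group on this amide-type nitrogen does matter, though swapping ethyl for methyl had shown nothing: hydrogen in place of methyl gives a 5.3-fold higher number from compound 3 to compound 4 (0.73 log units; beyond the scatter) and hydrogen in place of ethyl gives a 5.6-fold higher number from compound 1 to compound 4 (0.75 log units; beyond the scatter). Among these compounds, both alkyl groups go with stronger inhibition of growth than the amide hydrogen. No measured evidence here bears on the reason for this shift. Still open, on these data alone, is whether a propyl or a benzyl on this nitrogen stays level with methyl and ethyl.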